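This account rests on a few compounds, and the source may have more. Where it says the series, first, only, none or still open, it means among the compounds named here.

In a functional assay on A549 cells (Homo sapiens) for cytotoxicity, read by MTT assay, with a stated time of 72 h (on this read-out higher numbers stand for weaker inhibition and lower numbers for stronger inhibition), compound 3 `COc1cc2c(Oc3ccc(NC(=O)c4cn(-c5ccccc5OC)cn4)cc3F)ccnc2cc1OCCCN1CCCCC1` gives 120 nM, the second highest of the three numbers measured. Compound 1 `COc1cc2c(Oc3ccc(NC(=O)c4cn(-c5ccccc5OC)cn4)cc3F)ccnc2cc1OCCCN1CCN(C)CC1` gives 70 nM and compound 2 `COc1cc2c(Oc3ccc(NC(=O)c4cn(-c5cc(C)ccc5C)cn4)cc3F)ccnc2cc1OCCCN1CCN(C)CC1` gives 350 nM. The step of a 1.7-fold higher number from compound 1 to compound 3 (0.23 log units; within the scatter) lies within the scatter, whereas the step of a 5.0-fold higher number from compound 1 to compound 2 (0.70 log units; beyond the scatter) lies beyond it. Compound 4 `COc1cc2c(Oc3ccc(NC(=O)c4cn(-c5ccc(Cl)cc5)cn4)cc3F)ccnc2cc1OCCCN1CCCCC1` differs from compound 3 in one place: 4-chlorophenyl in place of 2-methoxyphenyl on an aromatic nitrogen. The step of a 5.0-fold higher number from compound 1 to compound 2 (0.70 log units; beyond the scatter) bears on this change: it too replaced the 2-methoxyphenyl on that aromatic nitrogen with a different phenyl, and the number rose. A modest upward step is therefore expected here as well. Compound 4 is expected to give 300 nM (range 100 nM to 900 nM). That corresponds to an expected step of a 2.5-fold higher number from compound 3 to compound 4 (0.40 log units; beyond the scatter).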

Compound 4, half-maximal inhibitory concentration: 6560 nM
Compound 4: the middle estimate sits 22-fold (1.34 log units) below what was measured; measured number outside the range, above it.
By their numbers in this assay, from the lowest: compounds 1 and 3 (each within the scatter of the next); then compound 2; then compound 4.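

In this assay, for the compounds shown here, the choice of phenyl group on this aromatic nitrogen can matter far more than the earlier compounds showed. Replacing 2-methoxyphenyl with 4-chlorophenyl gives a large loss (a 55-fold higher number from compound 3 to compound 4 (1.74 log units; beyond the scatter)), well beyond the modest one seen with 2,5-dimethylphenyl (a 5.0-fold higher number from compound 1 to compound 2 (0.70 log units; beyond the scatter)), although those two steps carry different amines on the chain. No measurement here explains this difference.

The change swaps the substituent and its ring position together, so 4-methoxyphenyl and 2-chlorophenyl would be needed to separate the two. As far as these compounds go, whether 4-chlorophenyl costs as much alongside 4-methylpiperazin-1-yl also remains open.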